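Hydroxyethyl to benzyl on the amide side chain

The compounds below may be only part of what the source reports. "The series", "measured", "known", "first", "only" and "open" are said of these compounds alone.

Compound 1 `O=C(NCCO)c1c(NO)cc(-c2ccc(F)cc2)oc1=O` and compound 2 `COc1ccc(-c2cc(NO)c(C(=O)NCCO)c(=O)o2)cc1` share one core and differ only by a methoxy in place of fluoro on an aromatic carbon. In an ADME assay on Huh-7 cells (Homo sapiens) for cytotoxicity, read by a luciferase reporter and WST assay, with a stated time of 3 days (a lower number here means that less compound is tolerated, a higher number that more compound is tolerated), compound 1 gives only a limit, > 20000 nM. Compound 2 likewise gives only a limit in this assay, > 20000 nM. The step that the two limits leave unreadable from compound 1 to compound 2 is therefore unreadable, as both values sit at the limit of > 20000 nM in this assay, at which 2 of the 2 values shown sit. Compound 2 thus stands at the limit, without a number of its own.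

Compound 3 `COc1ccc(-c2cc(NO)c(C(=O)NCc3ccccc3)c(=O)o2)cc1` differs from compound 2 by phenyl in place of hydroxymethyl on a saturated chain carbon bound to an amide-type nitrogen, read one bond further out as (2-hydroxyethyl)amino to benzylamino. No measured step touches this side chain; the only step shown, a step that the two limits leave unreadable from compound 1 to compound 2, lies on the aromatic ring and gives no size. The expected step of a number no higher from compound 2 to compound 3 (the limit leaves the size open) in this assay is therefore none beyond the scatter. Compound 3 is estimated at 20000 nM, between 8000 nM and 50000 nM, most likely reported again only as a limit.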

Compound 3, half-maximal cytotoxic concentration: > 20000 nM
Compound 3 gave a limit, no number; the forecaster's own chance of this, stated with the estimate: 70%; the middle value lies on the limit itself.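

No step can be read from compound 2 to compound 3 in this assay; compound 3 gives only a limit, as do the others: the limit of > 20000 nM in this assay, at which 3 of the 3 values shown sit.
The compounds shown leave open where the half-maximal cytotoxic concentration of each actually lies, and whether 2-hydroxyethyl to benzyl shifts it at all.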